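The source may report more compounds than this note shows. Statements on the series, on what has been measured and on what is new or still open speak of the compounds shown alone.

Compound 1 `c1cncc(CNCCCCN(C[C@H]2Cc3ccccc3CN2)[C@H]2CCCc3cccnc32)c1` is the starting point. In a functional assay on cells for agonist activity at C-X-C chemokine receptor type 4 (Homo sapiens), read by fluorescence and calcium flux, with a stated time of 90 s (a lower number here means that less compound is needed, a higher number that more compound is needed for the effect), compound 1 gives only a limit, > 30000 nM. Compound 2 `NCc1ccccc1CN(C[C@H]1Cc2ccccc2CN1)[C@H]1CCCc2cccnc21` likewise yields only a limit in this assay, > 30000 nM. Compound 3 `CC1(C)CCC(NC/C=C/CN(C[C@H]2Cc3ccccc3CN2)[C@H]2CCCc3cccnc32)CC1` also returns a limit in this assay, > 30000 nM. Compound 1 therefore stands at the limit of > 30000 nM in this assay, at which 3 of the 3 values shown sit, so no number sets it apart from the other two. Among the measured compounds shown here, the one step measured in a single place, a step that the two limits leave unreadable from compound 1 to compound 2, has no readable size for the same reason.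

Compound 4 `C(=C/CN(C[C@H]1Cc2ccccc2CN1)[C@H]1CCCc2cccnc21)\CNCc1cccnc1` differs from compound 1 by a group of 11 heavy atoms (9 carbon, 2 nitrogen; one six-membered aromatic ring with 1 hetero atom) in place of a group of 11 heavy atoms (9 carbon, 2 nitrogen; one six-membered aromatic ring with 1 hetero atom), on a saturated chain carbon bound to an amine nitrogen. The 3-(((pyridin-3-yl)methyl)amino)propyl group leaves, and a group of equal size carrying 1 double bond outside aromatic rings enters, on a saturated chain carbon bound to an amine nitrogen. For the measured compounds named here, no measured step reads this change directly; compound 3, whose structure also holds 1 double bond outside aromatic rings, sits at the limit as well. The expected step is therefore none beyond the scatter, a number no higher from compound 1 to compound 4 (the limit leaves the size open). Compound 4 is estimated in this assay at 30000 nM, within 8000 nM to 100000 nM, most likely again as a limit.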

Compound 4, half-maximal effective concentration: > 30000 nM
Compound 4 ended at the assay's limit; the forecaster's own chance of this, stated with the estimate: 75%; the middle value lies on the limit itself.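

In this assay compound 4 gives > 30000 nM, which is a limit, so its steps from compound 1, compound 2 and compound 3 cannot be read. The compounds shown leave open which change on the shared core, if any, would give a measurable value in this assay.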